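The source may report more compounds than this note shows. Statements on the series, on what has been measured and on what is new or still open speak of the compounds shown alone.

Three close relatives have been followed in an ADME assay on the whole organism (strain Sprague-Dawley) for metabolic stability, with Rattus norvegicus as the target; on this read-out lower numbers stand for a shorter-lived compound and higher numbers for a longer-lived compound. Compound 1 `C[C@H](c1ccc(N2CC[C@H](NS(=O)(=O)c3ccc4cc(Cl)ccc4c3)C2=O)c(F)c1)N(C)C` gives 2.6 h, and compound 2 `C[C@@H](c1ccc(N2CC[C@H](NS(=O)(=O)c3ccc4cc(Cl)ccc4c3)C2=O)c(F)c1)N(C)C` gives 2.1 h. Compound 3 `CN[C@H](C)c1ccc(N2CC[C@H](NS(=O)(=O)c3ccc4cc(Cl)ccc4c3)C2=O)c(F)c1` reaches 18 h, the highest of the three numbers. It carries 1-(methylamino)ethyl where the other two carry 1-(dimethylamino)ethyl, and the size of that exchange shows in a 6.9-fold higher number from compound 1 to compound 3 (0.84 log units; beyond the scatter) and in an 8.6-fold higher number from compound 2 to compound 3 (0.93 log units; beyond the scatter).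

Compound 4 `CN[C@@H](C)c1ccc(N2CC[C@H](NS(=O)(=O)c3ccc4cc(Cl)ccc4c3)C2=O)c(F)c1` has not yet been measured. Its difference from compound 3 is simple: the two compounds have the same atoms and bonds and differ only in configuration as drawn: 1 of 2 stereo elements differ; a stereocentre at a saturated chain carbon is drawn R in compound 3 and S in compound 4. No group leaves or enters, so the two steps that exchange 1-(dimethylamino)ethyl for 1-(methylamino)ethyl offer little guidance here. Going by the values given here, the one measured step of the same kind is a 1.2-fold lower number from compound 1 to compound 2 (0.09 log units; within the scatter), which shows that flipping a stereocentre at a saturated chain carbon made no difference beyond the scatter in that pair. This is thin support, since it is a single pair and both of its members carry 1-(dimethylamino)ethyl. No clear change is therefore expected in this assay, and the expected step is a 1.2-fold lower number from compound 3 to compound 4 (0.08 log units; within the scatter). The estimate for compound 4 is 15 h, with an expected range from 8 h to 28 h.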

Compound 4, half-life: 15 h
Estimate against measurement, compound 4: no gap at the digits printed, within the range that was stated.
By their numbers in this assay, from the lowest: compounds 2 and 1 (each within the scatter of the next); then compounds 4 and 3 (each within the scatter of the next).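

The flip at the saturated chain carbon has now been read with 1-(methylamino)ethyl as well as with 1-(dimethylamino)ethyl, and in this assay there is a 1.2-fold lower number from compound 3 to compound 4 (0.08 log units; within the scatter), so the drawn configuration at this carbon makes no clear difference in either pair: the fact that compounds 3 and 4 differ only in the configuration as drawn. Hydrogen in place of methyl on the amine nitrogen now has a second reading, a 7.1-fold higher number from compound 2 to compound 4 (0.85 log units; beyond the scatter), and it agrees with the first: the same change on two cores in this assay, a 6.9-fold higher number (0.84 log units; beyond the scatter) from compound 1 to compound 3 and a 7.1-fold higher number (0.85 log units; beyond the scatter) from compound 2 to compound 4, 1.0-fold (0.01 log units) apart, within the scatter of two such steps. The remaining comparison, a 5.8-fold higher number from compound 1 to compound 4 (0.76 log units; beyond the scatter), changes the configuration as well as the nitrogen group and points the same way, so across these four compounds the half-life follows the group on the nitrogen and not the drawn configuration at this carbon.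

Going by these compounds, all four compounds keep at least one methyl on this nitrogen, so it remains open whether a primary amine, or an ethyl group in place of that methyl, would carry the half-life further in the same direction. The half-life alone also does not tell what in the animal makes it longer.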